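Allyl in place of aminoethyl on a fluorinated benzamide

The source may report more compounds than this note shows. Statements on the series, on what has been measured and on what is new or still open speak of the compounds shown alone.

Compound 1 `Cc1nc2ccc(CN(CCN)c3ccc(C(=O)N[C@@H](CCC(=O)O)C(=O)O)c(F)c3)cc2c(=O)[nH]1`: 2700 nM
Compound 2 `C=CCN(Cc1ccc2nc(C)[nH]c(=O)c2c1)c1ccc(C(=O)N[C@@H](CCC(=O)O)C(=O)O)cc1F`: 140 nM
Compound 3 `CCN(Cc1ccc2nc(C)[nH]c(=O)c2c1)c1ccc(C(=O)N[C@@H](CCC(=O)O)C(=O)O)c(C)c1`: 1200 nM

In a functional assay on L1210 cells (Mus musculus) for inhibition (a lower number here means a stronger inhibitor, a higher number a weaker inhibitor), compound 1 gives 2700 nM, the highest number of the three measured compounds and therefore the weakest inhibitor of the set. Its nearest neighbour, compound 3, gives 1200 nM, a gap that lies beyond the scatter. Compound 2, furthest away, gives 140 nM, a large gap that is well beyond the scatter.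

The unmeasured compound 4 `C=CCN(Cc1ccc2nc(C)[nH]c(=O)c2c1)c1ccc(C(=O)N[C@@H](CCC(=O)O)C(=O)O)c(F)c1` is reached from compound 1 by a single change on the chain attached to the aromatic nitrogen: vinyl in place of aminomethyl on a saturated chain carbon bound to a nitrogen on an aromatic ring. The same allyl chain is present in compound 2, which differs from compound 4 only in the substituent pattern of the benzamide ring, and the value of compound 2 in this assay is far below that of compound 1. Compound 3, which carries a plain ethyl chain and a methyl group, still sits below compound 1.

Taken together, these numbers lead to the expectation that removing the aminoethyl chain and installing the allyl chain will lower the number substantially, and the step from compound 1 to compound 4 is estimated at a 14-fold lower number from compound 1 to compound 4 (1.13 log units; beyond the scatter). Compound 4 is therefore expected to give about 200 nM in this assay, within a range of 60 nM to 700 nM.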

Compound 4, half-maximal inhibitory concentration: 100 nM
Beside the measured number, compound 4's estimate is 2.0-fold (0.30 log units) above it; low and high end bracket the measured number.
By their numbers in this assay, from the lowest: compounds 4 and 2 (each within the scatter of the next); then compound 3; then compound 1.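

In this assay, exchanging 2-aminoethyl for allyl on a saturated chain carbon bound to a nitrogen on an aromatic ring, with the rest of the structure unchanged, gives a 27-fold lower number from compound 1 to compound 4 (1.43 log units; beyond the scatter), so the earlier contrast between these chains is now seen as a large effect of this single change alone. Compound 2, which also carries allyl but has a different substituent pattern on the benzamide ring, gives 140 nM and compound 4 gives 100 nM, values within the scatter of each other, so this assay does not separate these two allyl compounds. No measurement offered here accounts for the size of the step from the aminoethyl chain to the allyl chain.

The compounds shown leave open whether the step goes with losing the amine or with gaining the double bond, a question that a propyl chain or a propargyl chain at this place would address. Compound 3, with an ethyl chain, gives 1200 nM, but it also carries a methyl group on the benzamide ring, so it cannot settle how chain length alone counts.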